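Tolerance in Liver Cells: Estimating Compound 4

This account rests on a few compounds, and the source may have more. Where it says the series, first, only, none or still open, it means among the compounds named here.

Compound 1, `NC(=S)N1CCCc2c(OCCCCCOc3cccc4ccccc34)cccc21`: in an ADME assay on Huh-7 cells (Homo sapiens) for cytotoxicity (a higher number here means that more compound is tolerated, a lower number that less compound is tolerated), compound 1 gives > 50000 nM, a limit of the assay.
Compound 2, `NC(=S)n1ccc2c(OCCCCCOc3ccc(Cl)cc3)cccc21`: in this assay compound 2 gives 24700 nM.
Compound 3, `O=C(NC(=S)N1CCc2c(OCCCCCOc3ccc(Cl)cc3)cccc21)Oc1ccccc1`: in this assay compound 3 gives > 50000 nM, a limit of the assay.

Compound 3 therefore stands at the ceiling of what this assay reports, and it shares that position with compound 1, since (the limit of > 50000 nM in this assay, at which 2 of the 3 values shown sit). Among the measured compounds shown here, only compound 2 returns a number, and no step between two measured compounds is available to show how a single change moves the read-out.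

Compound 4, `O=C(NC(=S)N1CCc2c(OCCCCCOc3ccc(Cl)cc3)cccc21)c1ccc(F)cc1`, differs from compound 3 in one place: 4-fluorophenyl in place of phenoxy on a carbonyl carbon. Without a measured step to lean on, no shift beyond the usual scatter is expected in this assay in either direction, and compound 4 is expected to sit near the same limit as compound 3. The estimated step from compound 3 to compound 4 is a number no higher from compound 3 to compound 4 (the limit leaves the size open), and compound 4 is expected to give 50000 nM, with a range from 20000 nM to 100000 nM.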

Compound 4, half-maximal cytotoxic concentration: 31100 nM
Estimate against measurement, compound 4: 1.6-fold (0.21 log units) above, within the range that was stated.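

Replacing phenoxy with 4-fluorophenyl on a carbonyl carbon gives, in this assay, an at least 1.6-fold lower number from compound 3 to compound 4 (0.20 log units; that floor lies within the scatter). Among the compounds shown here, this is the first single-place change that can be read here, and it shows that compound 4, with the same core and chain as compound 3, returns a number and not a limit. How large the step really is stays unknown, and its floor alone does not establish a change beyond the scatter, because compound 3 holds only a limit: the limit of > 50000 nM in this assay, at which 2 of the 4 values shown sit.

The compounds shown leave open how other groups on this carbonyl carbon would read, such as methyl, a simple amine or 4-chlorophenyl. They also leave open whether the same exchange would read alike on the core of compound 1.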